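The source may hold more compounds than are shown below. What is called first, only, known or untested is meant among the compounds shown, and "the series" means these compounds.

In a functional assay on the whole organism with Mus musculus as the target (on this read-out lower numbers stand for an effect already at smaller amounts and higher numbers for an effect only at larger amounts of compound), three compounds on a shared core have been measured. Compound 1 `C[C@@H](NCc1ccc(OCCc2ccccc2)cc1)C(N)=O` gives 24.9 mg/kg, compound 2 `C[C@@H](NCc1ccc(OCc2ccc(F)cc2)cc1)C(N)=O` gives 132 mg/kg and compound 3 `C[C@@H](NCc1ccc(OCc2ccccn2)cc1)C(N)=O` gives 172 mg/kg. Compound 3 therefore sits level with compound 2, as the data show a 1.3-fold higher number from compound 2 to compound 3 (0.11 log units; within the scatter). The two larger gaps both start from compound 1: a 6.9-fold higher number from compound 1 to compound 3 (0.84 log units; beyond the scatter) and a 5.3-fold higher number from compound 1 to compound 2 (0.72 log units; beyond the scatter).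

Compound 4 `C[C@@H](NCc1ccc(OCc2ccsc2)cc1)C(N)=O` differs from compound 3 by thiophen-3-yl in place of pyridin-2-yl on a saturated chain carbon bound to an oxygen on an aromatic ring, which puts thiophen-3-yl in place of pyridin-2-yl on a saturated chain carbon bound to an oxygen on an aromatic ring. Among the measured compounds shown here, the closest precedent is the exchange of 4-fluorophenyl for pyridin-2-yl at this same place, which gave a 1.3-fold higher number from compound 2 to compound 3 (0.11 log units; within the scatter). The two larger steps both involve the loss of benzyl, which does not happen here. No shift beyond the scatter is therefore expected, and the estimated step is a 1.3-fold lower number from compound 3 to compound 4 (0.12 log units; within the scatter). Compound 4 is expected at about 130 mg/kg, with an estimated range from 55 mg/kg to 280 mg/kg.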

Compound 4, dose for half-maximal effect: 114 mg/kg
Beside the measured number, compound 4's estimate is 1.1-fold (0.06 log units) above it; the measured number falls inside the stated range.
By their numbers in this assay, from the lowest: compound 1; then compounds 4, 2 and 3 (each within the scatter of the next).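

In this assay, thiophen-3-yl on a saturated chain carbon bound to an oxygen on an aromatic ring stays level with the two other groups tested at this place (a 1.5-fold lower number from compound 3 to compound 4 (0.18 log units; within the scatter); a 1.2-fold lower number from compound 2 to compound 4 (0.06 log units; within the scatter)). A five-membered aromatic ring with sulfur thus joins pyridin-2-yl and 4-fluorophenyl in one level group, while benzyl remains apart from all three, as compound 4 also shows (a 4.6-fold higher number from compound 1 to compound 4 (0.66 log units; beyond the scatter)). Nothing available here accounts for either the level group or the separate position of benzyl.

Still open, going by these compounds, is whether a longer chain ending in phenyl would move the number further in the direction seen with benzyl in compound 1. On these data alone, it is equally open whether an aromatic ring carrying an amine or a carboxylic acid would stay level with compounds 2, 3 and 4.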